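The source may report more compounds than this note shows. Statements on the series, on what has been measured and on what is new or still open speak of the compounds shown alone.

Measured compounds:
- compound 1, `Cc1c(C(=O)N/N=C\c2cccc(O)c2)oc2cccc(O)c12`, 17600 nM
- compound 2, `Cc1c(C(=O)N/N=C\c2c(O)cccc2F)oc2cccc(O)c12`, 8050 nM
- compound 3, `Cc1c(C(=O)N/N=C\c2cc(Cl)ccc2O)oc2cccc(O)c12`, 3120 nM

In a functional assay on PC-3 cells (Homo sapiens) for inhibition (a lower number here means a stronger inhibitor, a higher number a weaker inhibitor), compound 3 gives the lowest number of the three. Its nearest neighbour is compound 2, which gives 8050 nM, and the furthest is compound 1, which gives 17600 nM. The steps between the measured compounds are all modest: a 2.2-fold lower number from compound 1 to compound 2 (0.34 log units; beyond the scatter), a 5.6-fold lower number from compound 1 to compound 3 (0.75 log units; beyond the scatter) and a 2.6-fold lower number from compound 2 to compound 3 (0.41 log units; beyond the scatter).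

Compound 4, `Cc1c(C(=O)N/N=C\c2ccc(F)cc2)oc2cccc(O)c12`, is not yet measured. It differs from compound 3 in one place: 4-fluorophenyl in place of 5-chloro-2-hydroxyphenyl on a carbon with a double bond to nitrogen. Among the compounds with values here, no measured step removes the hydroxyl from this ring; every measured compound carries one. The measured steps show that the 5-chloro-2-hydroxyphenyl gave the lowest number, so its loss is expected to raise the number in this assay, most likely back toward the region of compound 1 and compound 2, with the step of a 3.8-fold higher number from compound 3 to compound 4 (0.59 log units; beyond the scatter) beyond the scatter but of modest size. For compound 4 the estimated value in this assay is 12000 nM, with a range from 4000 nM to 40000 nM.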

Compound 4, half-maximal inhibitory concentration: >= 40000 nM
Compound 4 gave a limit, no number; the forecaster's own chance of this, stated with the estimate: 15%; middle value at least 3.3-fold (0.52 log units) from the limit.
By their numbers in this assay, from the lowest: compound 3; then compound 2; then compound 1. At a limit, above all of these: compound 4.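

Compound 4 gives only a limit in this assay, not a number, and each step to it is therefore a lower bound: the limit of >= 40000 nM in this assay, at which 1 of the 4 values shown sits. The steps are an at least 12-fold higher number from compound 3 to compound 4 (1.10 log units; beyond the scatter), an at least 4.9-fold higher number from compound 2 to compound 4 (0.69 log units; beyond the scatter) and an at least 2.2-fold higher number from compound 1 to compound 4 (0.35 log units; beyond the scatter). Within the data shown here, all the earlier compounds carry a hydroxyl on this ring and differ from one another only modestly, whereas the 4-fluorophenyl, which carries none, shows that a change on this carbon with a double bond to nitrogen can cost far more than those compounds revealed.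

The change to compound 4 removes the hydroxyl and alters the halogen in a single step, so the compounds shown do not separate the two. They also leave open whether a methoxy or an amine in place of that hydroxyl would keep the number low.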